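The compounds below may be only part of what the source reports. "The series", "measured", "known", "first", "only" and "open" are said of these compounds alone.

Compound 1 `COc1cccc(-c2nc3cccc(-c4cc(OC)c(OC)c(OC)c4)c3o2)c1` gives only a limit in a functional assay on U-251 cells (Homo sapiens) for antiproliferative activity, read by MTT assay, with a stated time of 48 h; a lower number here means a stronger inhibitor, a higher number a weaker inhibitor: its reading of > 25000 nM is an assay limit rather than a number. Compound 2 `COc1cc(-c2cccc3nc(-c4cccc(F)c4)oc23)cc(OC)c1OC` gives 2900 nM in this assay. Among the compounds with values here, the single measured step, an at least 8.6-fold lower number from compound 1 to compound 2 (0.93 log units; beyond the scatter), rests on that limit of > 25000 nM in this assay, at which 1 of the 2 values shown sits, and concerns a different change. Compound 3 `COc1cc(-c2nc3cccc(-c4cc(OC)c(OC)c(OC)c4)c3o2)ccc1O` differs from compound 1 by hydroxy in place of hydrogen on an aromatic carbon, so 3-methoxyphenyl becomes 4-hydroxy-3-methoxyphenyl. Within the data shown here, no measured step covers this change, and the starting point is itself a limit, so compound 3 is expected to stay weak, with an at least 1.2-fold lower number from compound 1 to compound 3 (0.09 log units; that floor lies within the scatter) the estimated step. Compound 3 is therefore estimated at 20000 nM, within 4000 nM to 80000 nM.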

Compound 3, half-maximal inhibitory concentration: 10300 nM
The estimate for compound 3 lay 1.9-fold (0.29 log units) above the measured number; measured number inside the range.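

In this assay, hydroxy in place of hydrogen on the aromatic carbon ortho to the methoxy group gives an at least 2.4-fold lower number from compound 1 to compound 3 (0.38 log units; beyond the scatter). Compound 1 stands at a limit of the assay, not at a number: the limit of > 25000 nM in this assay, at which 1 of the 3 values shown sits. Even with the hydroxy, 4-hydroxy-3-methoxyphenyl does not reach 3-fluorophenyl, with a 3.6-fold higher number from compound 2 to compound 3 (0.55 log units; beyond the scatter). As far as these compounds go, what an amine or a carboxylic acid at this same place on the ring would give stays open. So does whether hydroxy would lower the number further on the 3-fluorophenyl ring of compound 2.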